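A few compounds are considered here, and "the series" means these few. Any claim that something is new, unique, unknown or untested is made for them only; others in the source may bear on it.

Compound 1 `COc1cc(-c2cc(/C=C/C(=O)c3ccc(N)cc3)[nH]n2)cc(OC)c1OC` gives 1400 nM in a functional assay on OVCAR-4 cells (Homo sapiens) for inhibition, read by sulforhodamine B assay, with a stated time of 48 h; a higher number here means a weaker inhibitor of growth, a lower number a stronger inhibitor of growth; compound 2 `COc1ccc(C(=O)/C=C/c2cc(-c3cc(OC)c(OC)c(OC)c3)n[nH]2)cc1OC` gives 2690 nM.

Compound 2 thus has the highest of the two numbers, with compound 1 the nearest, and the step of a 1.9-fold higher number from compound 1 to compound 2 (0.28 log units; within the scatter) lies within the scatter. Compound 3 `COc1ccc(C(=O)/C=C/c2cc(-c3cc(OC)c(OC)c(OC)c3)n[nH]2)cc1` differs from compound 2 by hydrogen in place of methoxy on an aromatic carbon. For the measured compounds named here, the only measured step concerns the same ring, but exchanges the whole group rather than trimming a methoxy, and it was small. Going by the values given here, no measured step speaks directly to losing one methoxy, so no change beyond the scatter is expected, with a 1.1-fold lower number from compound 2 to compound 3 (0.03 log units; within the scatter). Compound 3 is therefore estimated at 2500 nM, between 900 nM and 7000 nM.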

Compound 3, concentration for 50% growth inhibition: 2200 nM
Estimate against measurement, compound 3: 1.1-fold (0.06 log units) above; the measured number falls inside the stated range.
By their numbers in this assay, from the lowest: compounds 1, 3 and 2 (each within the scatter of the next).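

Going from 3,4-dimethoxyphenyl to 4-methoxyphenyl, with hydrogen in place of methoxy, gives a 1.2-fold lower number from compound 2 to compound 3 (0.09 log units; within the scatter) in this assay and so shows directly that losing this one methoxy leaves the number within the scatter. Methoxy in place of amino on the same ring gives a 1.6-fold higher number from compound 1 to compound 3 (0.20 log units; within the scatter) as well, so this single-group exchange also stays inside the scatter. No measurement at hand offers an explanation for either step. Still open, going by these compounds, is whether a hydroxyl group, a fluorine atom or a carboxylic acid in place of that methoxy would move the number beyond the scatter.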